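Swapping the Dimethylamino Chain End for a Hydroxy Group

The compounds below may be only part of what the source reports. "The series", "measured", "known", "first", "only" and "open" are said of these compounds alone.

Measured compounds:
Compound 1, `CN(C)CCCNC1=Nc2ccc(Cl)cc2C(C)(C)C1`: 54.1%
Compound 2, `CN(C)CCCNC1=Nc2cccc(Cl)c2C(C)(C)C1`: 60.5%

Among the measured compounds shown here, in a functional assay on MDA-MB-231 cells (Homo sapiens) for cytotoxicity, read by MTT assay, with a stated time of 72 h, tested at 1 uM, in the absence of a further agent (a lower number here means a stronger effect, a higher number a weaker effect of the compound at the concentration tested), compound 1 gives 54.1%, the lower of the two numbers measured so far. Its nearest neighbour is compound 2, which in this assay gives 60.5%; the gap between the two lies within the usual scatter, so no order between them can be claimed. For the measured compounds named here, no step between measured compounds that differ in a single place exists in this set, so the next compound has to be judged without a direct precedent.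

Compound 3, `CC1(C)CC(NCCCO)=Nc2ccc(Cl)cc21`, has not yet been measured in this assay. It differs from compound 1 in one place: hydroxy in place of dimethylamino on a saturated chain carbon, three bonds along the chain from an amine nitrogen. Going by the values given here, with no measured step of this kind to lean on, the expected change rests on the structural difference alone. The number for compound 3 is expected to come out above that of compound 1, meaning a weaker effect, a step of a number 15.9 percentage points higher from compound 1 to compound 3 (beyond the scatter), though a step no larger than the scatter cannot be excluded. The estimated value for compound 3 is 70%, with a range from 50% to 95%.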

Compound 3, a percentage reported as activity, at one concentration (the size of the read-out at that concentration, not a potency): 84.5%
Compound 3: middle estimate off by 14.5 percentage points, on the low side, within the range that was stated.
By their numbers in this assay, from the lowest: compounds 1 and 2 (each within the scatter of the next); then compound 3.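

In this assay, hydroxy in place of dimethylamino on a saturated chain carbon, three bonds along the chain from an amine nitrogen, gives a number 30.4 percentage points higher from compound 1 to compound 3 (beyond the scatter), a large loss of effect at the single concentration tested. Among the compounds shown here, this is the first single-place step in the set, and it shows that the end of this chain is a place where one exchange can move the read-out well beyond the usual spread of repeated measurements, which compounds 1 and 2 alone could not show. The compounds shown offer no measurement that bears on why the effect weakens with this exchange.

Going by these compounds, it remains open whether the step follows from losing dimethylamino or from introducing hydroxy, a question that a methoxy group, a primary amine or a morpholine at the chain end would help to separate. On these data alone, it is also open whether other ends on a shorter or longer chain would keep the effect of compound 1, and how far this one exchange carries over to compound 2.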